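The source may hold more compounds than are shown below. What is called first, only, known or untested is meant among the compounds shown, and "the series" means these compounds.

In a physicochemical assay for lipophilicity, at pH 7.4 (on this read-out lower numbers stand for lower lipophilicity and higher numbers for higher lipophilicity), every reading so far is a limit and not a number:
compound 1 (`Cc1cc(S(=O)(=O)NCCCC[C@@H](Nc2cc(C)c(F)c(C)c2)C(=O)NO)ccc1F`) gives < 3
compound 2 (`Cc1cc(N[C@H](CCCCNCc2cccc(F)c2)C(=O)NO)cc(C)c1F`) gives < 3
compound 3 (`Cc1cc(N[C@H](CCCCNCc2ccc(C(F)(F)F)cc2)C(=O)NO)cc(C)c1F`) gives < 3

Compound 2 stands at < 3 as a limit, with no number known. The whole set looks the same (the limit of < 3 in this assay, at which 3 of the 3 values shown sit). The change to compound 4 (`Cc1cc(N[C@H](CCCCNCCCc2ccc(F)cc2)C(=O)NO)cc(C)c1F`) reads 2-(4-fluorophenyl)ethyl in place of 3-fluorophenyl on a saturated chain carbon bound to an amine nitrogen with 2-(4-fluorophenyl)ethyl in place of 3-fluorophenyl on a saturated chain carbon bound to an amine nitrogen. Within the data shown here, the only measured change at that place is a step that the two limits leave unreadable from compound 2 to compound 3 and it offers no size to carry over. No shift beyond the scatter is therefore expected in this assay (expected: a step that the limit leaves unreadable from compound 2 to compound 4) and no direction can be set. Estimated for compound 4 is 2.5 with an expected range of 1.8 to 3.2 and a reading at the limit is likely.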

Compound 4, distribution coefficient: < 3
Compound 4: a limit, no number; the forecaster's own chance of this, stated with the estimate: 75%; the middle value is on the limit's open side.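

In this assay, among these compounds, compound 2, compound 3 and compound 4 all read as limits, so no step among them can be read: the limit of < 3 in this assay, at which 4 of the 4 values shown sit. The compounds shown leave open the actual values of all four compounds, and with them the size and direction of any step.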